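Swapping the Sulfonyl Cap for an Ethyl Group

The compounds below may be only part of what the source reports. "The series", "measured", "known", "first", "only" and "open" are said of these compounds alone.

Compound 1, `Cn1nc2c(=O)n(CC3(O)CCN(Cc4ccc(-c5ccco5)cc4Cl)CC3)cnc2c1-c1ccc(CNS(C)(=O)=O)cc1`: 65.3 nM
Compound 2, `Cn1nc2c(=O)n(CC3(O)CCN(Cc4ccc(-c5ccoc5)cc4Cl)CC3)cnc2c1-c1ccc(CN)cc1`: 177 nM
Compound 3, `Cn1nc2c(=O)n(CC3(O)CCN(Cc4ccc(-c5ccncc5)cc4Cl)CC3)cnc2c1-c1ccc(CN)cc1`: 257 nM

In an assay on isolated protein for inhibition of ubiquitin carboxyl-terminal hydrolase 7 (Homo sapiens), with stated times of 30 min and 2 h (on this read-out lower numbers stand for stronger inhibition and higher numbers for weaker inhibition), compound 1 gives the lowest of the three numbers, and its gaps to compound 2 and to compound 3 both lie beyond the scatter. Compounds 2 and 3 differ from compound 1 in two places each, so their values do not isolate a single change. Going by the values given here, the only single-change step measured, a 1.5-fold higher number from compound 2 to compound 3 (0.16 log units; within the scatter), concerns a ring on an aromatic carbon and not the group altered here.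

Compound 4 is `CCNCc1ccc(-c2c3ncn(CC4(O)CCN(Cc5ccc(-c6ccco6)cc5Cl)CC4)c(=O)c3nn2C)cc1`. Relative to compound 1 the change is ethyl in place of methylsulfonyl on an amine nitrogen. Among the compounds with values here, no measured step covers this change, so the expectation rests only on the spread of the three numbers. Compound 4 is expected to give a somewhat higher number, near the middle of that spread, estimated as 120 nM with a range of 40 nM to 350 nM. The estimated step is a 1.8-fold higher number from compound 1 to compound 4 (0.26 log units; within the scatter), with wide uncertainty.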

Compound 4, half-maximal inhibitory concentration: 15.2 nM
Compound 4: middle estimate off by 7.9-fold (0.90 log units), on the high side; the measured number lies below the stated range.
By their numbers in this assay, from the lowest: compound 4; then compound 1; then compounds 2 and 3 (each within the scatter of the next).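

In this assay, ethyl in place of methylsulfonyl on the amine nitrogen gives a 4.3-fold lower number from compound 1 to compound 4 (0.63 log units; beyond the scatter) and this step lies beyond the scatter. Going by these compounds alone, it is the first measured step at this position, and it shows that inhibition here does not depend on keeping the methylsulfonyl group: ethyl, with 2 heavy atoms in place of 4 and no hydrogen-bond acceptors, gives the lower number. Nothing in the available data explains why the number falls.

As far as these compounds go, this reading rests on a single pair of compounds, so it remains open whether the same change would give a similar step with a different ring in place of the furan. From the compounds shown here alone, it is also open how the number would respond to a propyl chain, a cyclopropyl ring or an acetyl group on this nitrogen.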